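Swapping fluorine position on the benzyl group of a dithiocarbamate

The source may hold more compounds than are shown below. What is called first, only, known or untested is meant among the compounds shown, and "the series" means these compounds.

Measured so far in a functional assay on 4T1 cells (Mus musculus) for cytotoxicity, read by MTT assay, with a stated time of 24 h; on this read-out lower numbers stand for stronger inhibition and higher numbers for weaker inhibition:
- compound 1, `COc1ccc(/C=C2\CN(C(=S)SCc3cn(Cc4ccccc4F)nn3)C/C(=C\c3ccc(OC)cc3)C2=O)cc1`, gives 49900 nM
- compound 2, `COc1ccc(/C=C2\CN(C(=S)SCc3cn(Cc4ccc(F)cc4)nn3)C/C(=C\c3ccc(OC)cc3)C2=O)cc1`, gives > 100000 nM
- compound 3, `O=C1/C(=C/c2ccccc2F)CN(C(=S)SCc2cn(Cc3ccccc3F)nn2)C/C1=C\c1ccccc1F`, gives 30700 nM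

The number reported for compound 2 is a limit of this assay rather than a measured value. Compound 1 and compound 2 share a core and differ only in 4-fluorophenyl in place of 2-fluorophenyl on a saturated chain carbon bound to an aromatic nitrogen. That change made an at least 2.0-fold higher number from compound 1 to compound 2 (0.30 log units; that floor lies within the scatter). The size of this step is known only as a floor, because of the limit of > 100000 nM in this assay, at which 1 of the 3 values shown sits.

Compound 3 carries a different core; the difference between the two cores is not broken down here. Against compound 1, compound 3 gives a number that is lower but within the scatter, so no order between the two can be claimed.

Compound 4, `O=C1/C(=C/c2ccccc2F)CN(C(=S)SCc2cn(Cc3ccc(F)cc3)nn2)C/C1=C\c1ccccc1F`, has not yet been measured. It relates to compound 3 exactly as compound 2 relates to compound 1: the difference is 4-fluorophenyl in place of 2-fluorophenyl on a saturated chain carbon bound to an aromatic nitrogen, and since the place of the change is described in the same words in both pairs, this is the same change made on a second core. Among the measured compounds shown here, the only guide is the step seen from compound 1 to compound 2, which reached a limit. On that basis compound 4 is expected to show a 2.3-fold higher number from compound 3 to compound 4 (0.36 log units; beyond the scatter), with a real chance that this assay again reports only a limit. Compound 4 is expected to give about 70000 nM, between 30000 nM and 150000 nM.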

Compound 4, half-maximal inhibitory concentration: 9900 nM
Compound 4: middle estimate off by 7.1-fold (0.85 log units), on the high side; measured number below the stated range.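

On the core of compound 3, replacing 2-fluorobenzyl with 4-fluorobenzyl gives a 3.1-fold lower number from compound 3 to compound 4 (0.49 log units; beyond the scatter), so on this core the change goes with stronger inhibition in this assay. The same change does not do the same thing on the two cores, and the two steps clearly differ: the same change on two cores in this assay, an at least 2.0-fold higher number (0.30 log units; that floor lies within the scatter) from compound 1 to compound 2 and a 3.1-fold lower number (0.49 log units; beyond the scatter) from compound 3 to compound 4, at least 6.2-fold (0.79 log units) apart, beyond the scatter of two such steps

Compound 2 gives > 100000 nM, which is a limit and not a number, so the step on the core of compound 1 is known only as a floor; what is shown is that the outcome of this swap depends on the core carrying it, not why it does so, and two pairs of compounds make no general rule for the series.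

The compounds shown leave open whether a third core would behave like the core of compound 1 or like the core of compound 3, and how a benzyl group without fluorine or a chlorobenzyl group would compare at the same place. They also leave open whether the lower number of compound 4 would hold on any cell type other than the one used in this assay.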